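Bromo on the benzyl ring in a nitro chalcone triazole

This account rests on a few compounds, and the source may have more. Where it says the series, first, only, none or still open, it means among the compounds named here.

Measured compounds:
compound 1, `O=C(/C=C/c1ccc(OCc2cn(Cc3ccccc3Br)nn2)cc1)c1ccc(Br)cc1`, gives 44%
compound 2, `COc1ccc(C(=O)/C=C/c2ccc(OCc3cn(Cc4ccccc4Br)nn3)cc2)cc1`, gives 60%
compound 3, `O=C(/C=C/c1ccc(OCc2cn(Cc3ccccc3)nn2)cc1)c1ccc([N+](=O)[O-])cc1`, gives "not active" (no number reported)

All three share one core; they were tested in a functional assay on MCF7 cells (Homo sapiens) for inhibition, read by MTT assay, with a stated time of 48 h, tested at 10 uM; on this read-out lower numbers stand for less inhibition of growth and higher numbers for more inhibition of growth at the one concentration tested. Compound 1 and compound 2 both carry a bromobenzyl group on the triazole and differ only on the aryl ketone, and the step of a number 16 percentage points higher from compound 1 to compound 2 (beyond the scatter). Compound 3 carries an unsubstituted benzyl group and a nitro on the aryl ketone; for compound 3 this assay gives no number, only the statement that it was not active, so compound 3 stands below the two numbered compounds without a measured distance to them.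

Compound 4, `O=C(/C=C/c1ccc(OCc2cn(Cc3ccccc3Br)nn2)cc1)c1ccc([N+](=O)[O-])cc1`, is compound 3 with bromo in place of hydrogen on an aromatic carbon. Going by the values given here, no measured step covers this change: the one recorded step concerns the aryl ketone and not the benzyl ring, and compounds 1 and 2 differ from compound 3 in two places at once, so they show only that bromobenzyl compounds with other ketone substituents gave moderate inhibition. The direction of the change is therefore open; the nitro ketone of compound 3 gave no activity, which weighs toward a low value, while the bromo benzyl group is shared with compounds 1 and 2.

Compound 4 is expected, with wide uncertainty, to give 30%, in the range 5% to 60%.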

Compound 4, percent growth inhibition at one concentration: 43%
Compound 4: the middle estimate sits 13 percentage points below what was measured; the measured number falls inside the stated range.
By their numbers in this assay, from the lowest: compounds 4 and 1 (each within the scatter of the next); then compound 2.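

In this assay, benzyl to 2-bromobenzyl with the nitro ketone held fixed separates compound 3, reported only as not active, from compound 4 (43%), so bromo on this ring, ortho to a large group, goes with measurable growth inhibition in this pair, although the size of the step cannot be read without a number for compound 3. Among the three 2-bromobenzyl compounds, nitro in place of methoxy lowers the value (step: a number 17 percentage points lower from compound 2 to compound 4 (beyond the scatter)), whereas nitro and bromo on the aryl ketone cannot be told apart (step: a number 1 percentage points lower from compound 1 to compound 4 (within the scatter)), so a nitro ketone is compatible with measurable inhibition when the 2-bromobenzyl group is present, and only compound 2 stands apart from the other two. No available data bear on the reason for these differences.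

From the compounds shown here alone, whether the link between bromo and measurable inhibition holds with a methoxy or bromo ketone remains open, as the pair rests on a single ketone substituent. Also open, going by these compounds, is how a chloro or methyl group at the same place on the benzyl ring, or a dimethylamino group or carboxylic acid on the aryl ketone, would read here.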